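The compounds below may be only part of what the source reports. "The series", "measured", "known", "first", "only" and "open" are said of these compounds alone.

The measured compounds:

- compound 1, `CCCCc1ccc(-c2cc(Cl)cc(C(=O)Nc3nn[nH]n3)n2)cc1`: in a functional assay on the whole organism with Rattus norvegicus as the target, at a dose of 3 mg/kg by the oral route (a lower number here means a weaker effect, a higher number a stronger effect of the compound at the dose given), compound 1 gives 83%
- compound 2, `COc1cc(C(=O)Nc2nn[nH]n2)nc(-c2cccc(Cl)c2)c1`: in this assay compound 2 gives 34%
- compound 3, `COc1ccc(-c2cc(OC)cc(C(=O)Nc3nn[nH]n3)n2)cc1`: in this assay compound 3 gives 60%

All three share the same core, an amide linking a substituted pyridine to a tetrazole, and differ only in the groups hanging from it. Compound 3 stands second of the three numbers: compound 1 lies higher and compound 2 lower, and both gaps are beyond the usual scatter of this kind of measurement.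

Compound 4, `CCCCc1ccc(-c2cc(OC)cc(C(=O)Nc3nn[nH]n3)n2)cc1`, has not yet been measured. It differs from compound 3 in one place: butyl in place of methoxy on an aromatic carbon.

Among the measured compounds shown here, only one single-point step is available among the measured compounds, a number 26 percentage points higher from compound 2 to compound 3 (beyond the scatter). It shows that exchanging the group on that phenyl ring can shift the read-out by a modest amount, but it does not involve butyl, so it bears only loosely on the present change. For the measured compounds named here, compound 1 carries the same butyl-bearing ring as compound 4 but also differs from compound 3 on the pyridine, so no clean step can be drawn from it; its value simply sits above that of compound 3.

For compound 4 a value of 74% is therefore expected, within 55% to 92%. This amounts to an expected step of a number 14 percentage points higher from compound 3 to compound 4 (beyond the scatter), upward but of uncertain size.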

Compound 4, a percentage reported as inhibition, in the whole organism at one dose (the size of the read-out at that dose, not a potency): 61%
Compound 4: the middle estimate sits 13 percentage points above what was measured; low and high end bracket the measured number.
By their numbers in this assay, from the lowest: compound 2; then compounds 3 and 4 (each within the scatter of the next); then compound 1.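

In this assay, putting butyl in place of methoxy on the six-membered aromatic ring of carbon only, para to a large group, gives a number 1 percentage points higher from compound 3 to compound 4 (within the scatter). At this place, then, and with the methoxy elsewhere on the molecule kept, a chain of carbons and an oxygen-linked group give read-outs that cannot be told apart, even though the two groups differ in size and in hydrogen-bond acceptors. With butyl kept at this place, the other change does register, with a number 22 percentage points lower from compound 1 to compound 4 (beyond the scatter), so the higher read-out of compound 1 goes with the chloro rather than with the butyl alone. No measurement here explains either result.

The compounds shown leave open whether butyl and methoxy would also match at this place when chloro replaces the other methoxy, since only the butyl member of that pair appears. They also leave open how this assay would respond at this place to a longer chain, an amine or a carboxylic acid, and a single dose gives no measure of potency for any of these compounds.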